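A few compounds are considered here, and "the series" means these few. Any claim that something is new, unique, unknown or untested is made for them only; others in the source may bear on it.

Measured in a functional assay on HT-29 cells (Homo sapiens) for inhibition; on this read-out higher numbers stand for weaker inhibition and lower numbers for stronger inhibition:
- Compound 1 `COc1ccc(/C=C\c2ccc3ccccc3c2)cc1[N+](=O)[O-]`: 3280 nM.
- Compound 2 `COc1cc(/C=C/c2ccc(N(C)C)c([N+](=O)[O-])c2)cc(OC)c1OC`: > 5000 nM, a limit.
- Compound 3 `COc1cc(/C=C\c2ccc(N(C)C)c([N+](=O)[O-])c2)cc(OC)c1OC`: > 5000 nM, a limit.

Compound 2 has no number in this assay, only the limit > 5000 nM. Compound 4 `COc1cc(/C=C/c2ccc(N(C)C)c(N)c2)cc(OC)c1OC` derives from it by a single exchange: amino in place of nitro on an aromatic carbon. The amino group takes the place of the nitro group on an aromatic carbon, ortho to a dimethylamino group.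

Within the data shown here, the one measured step nearby is a step that the two limits leave unreadable from compound 2 to compound 3. It concerns only (the fact that compounds 2 and 3 differ only in the configuration as drawn), so it does not show what this exchange does. Compound 1 gives a number, 3280 nM, but it differs from compound 2 in more than one place and offers no measured comparison for the exchange. With no size or direction to carry over, no step beyond the scatter is expected, although a change in either direction remains possible.

The expected change is a number no higher from compound 2 to compound 4 (the limit leaves the size open). Compound 4 is estimated at 5000 nM in this assay, with an expected range from 1000 nM to 20000 nM.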

Compound 4, half-maximal inhibitory concentration: 300 nM
Beside the measured number, compound 4's estimate is 17-fold (1.22 log units) above it; measured number below the stated range.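

In this assay, the aromatic carbon ortho to a dimethylamino group proves sensitive to the group it carries: amino in place of nitro gives an at least 16-fold lower number from compound 2 to compound 4 (1.22 log units; beyond the scatter). Among these compounds, the earlier compounds could not show this, as the one step among them cannot be read and concerns configuration only, while compound 1 offers no comparison for this exchange. The step has a lower bound on its size and no exact value, as it starts from a limit rather than a number: the limit of > 5000 nM in this assay, at which 2 of the 4 values shown sit.

Going by these compounds, whether a hydroxyl, a methoxy or an acetamide at this place would match the amino group remains open. Also open, on these data alone, is whether the amino group has the same effect when the double bond is drawn Z, as it is in compound 3.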